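This account rests on a few compounds, and the source may have more. Where it says the series, first, only, none or still open, it means among the compounds named here.

In a functional assay for inhibition, with Homo sapiens as the target (on this read-out higher numbers stand for weaker inhibition and lower numbers for stronger inhibition), compound 2 (`O=C(O)CCNC(=O)c1cc2cc(OCC3CCNCC3)ccc2[nH]1`) gives 1000 nM, level within the scatter with compound 3 (`O=C(O)CC(NC(=O)c1cc2cc(OCC3CCNCC3)ccc2[nH]1)c1cccnc1`) at 810 nM. Compound 1 (`O=C(NC[C@H](NS(=O)(=O)c1ccccc1)C(=O)O)c1cc2ccc(OCC3CCNCC3)cc2[nH]1`) gives a far lower number, 15 nM.

Compound 4 (`Cc1ccc(S(=O)(=O)N[C@@H](CNC(=O)c2cc3cc(OCC4CCNCC4)ccc3[nH]2)C(=O)O)cc1`) follows from compound 2 by one change: ((4-methylphenyl)sulfonyl)amino in place of hydrogen on a saturated chain carbon bound to a carbonyl carbon and a saturated chain carbon.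

Going by the values given here, the only measured step, a 1.2-fold lower number from compound 2 to compound 3 (0.09 log units; within the scatter), lies within the scatter, but it adds pyridin-3-yl on a different chain carbon, so it bears only weakly on this change. Compound 1 also carries a sulfonylamino group, but it differs from compound 2 in more than one place, so the value of compound 1, 15 nM, is only a loose guide.

A large drop beyond the scatter is expected in this assay, estimated as a 25-fold lower number from compound 2 to compound 4 (1.40 log units; beyond the scatter). For compound 4 the estimated value is 40 nM, with an expected range of 10 nM to 200 nM.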

Compound 4, half-maximal inhibitory concentration: 6 nM
Beside the measured number, compound 4's estimate is 6.7-fold (0.82 log units) above it; the measured number lies below the stated range.
By their numbers in this assay, from the lowest: compound 4; then compound 1; then compounds 3 and 2 (each within the scatter of the next).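

In this assay, going by these compounds alone, ((4-methylphenyl)sulfonyl)amino on the saturated chain carbon bound to a carbonyl carbon and a saturated chain carbon gives a 170-fold lower number from compound 2 to compound 4 (2.22 log units; beyond the scatter), the only large single-place step. The other such step, a 1.2-fold lower number from compound 2 to compound 3 (0.09 log units; within the scatter), puts pyridin-3-yl on a different chain carbon and stays within the scatter. No measurement at hand accounts for the size of the new step.

The compounds shown leave open which part of the entering group carries the step. A plain amine or an acetylamino group on the same carbon would test this.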